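Chain Extension on a Triazole Side Arm in HeLa Cells

The source may hold more compounds than are shown below. What is called first, only, known or untested is meant among the compounds shown, and "the series" means these compounds.

Measured compounds:
- compound 1, `O=c1cc(Cn2cc(CCCCl)nn2)c2ccc(O)cc2o1`: 49600 nM
- compound 2, `CCCCCCc1cn(Cc2cc(=O)oc3cc(O)ccc23)nn1`: 59000 nM

The two measured compounds were tested in a functional assay on HeLa cells (Homo sapiens) for inhibition, read by MTT assay, with a stated time of 72 h; on this read-out higher numbers stand for weaker inhibition and lower numbers for stronger inhibition. Compound 1 gives 49600 nM, while compound 2 gives 59000 nM. Among these two numbers compound 1 stands lowest, but its single neighbour is compound 2, and the step of a 1.2-fold higher number from compound 1 to compound 2 (0.08 log units; within the scatter) lies within the scatter, so neither compound can be called more potent than the other.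

The new compound is compound 3, `CCCCCCCCc1cn(Cc2cc(=O)oc3cc(O)ccc23)nn1`. Relative to compound 1 it differs as follows: pentyl in place of chloro on a saturated chain carbon, three bonds along the chain from an aromatic carbon

Going by the values given here, the only measured step that bears on this change is a 1.2-fold higher number from compound 1 to compound 2 (0.08 log units; within the scatter), where a shorter alkyl group took the place of the same chloro on the same chain carbon and the number did not move beyond the scatter. Compound 3 carries a longer chain still, so the data offer no indication of a step in either direction. On that basis compound 3 is expected to give about 60000 nM, between 30000 nM and 120000 nM, amounting to an estimated step of a 1.2-fold higher number from compound 1 to compound 3 (0.08 log units; within the scatter).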

Compound 3, half-maximal inhibitory concentration: 35100 nM
Estimate against measurement, compound 3: 1.7-fold (0.23 log units) above; measured number inside the range.
By their numbers in this assay, from the lowest: compounds 3, 1 and 2 (each within the scatter of the next).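

In this assay, the exchange of chloro for pentyl on a saturated chain carbon, three bonds along the chain from an aromatic carbon, gives a 1.4-fold lower number from compound 1 to compound 3 (0.15 log units; within the scatter) and so extends the earlier reading to a larger alkyl group: with 5 heavy atoms entering for 1, the number still cannot be told apart from that of the chloro compound. The new compound also opens a second comparison, ethyl in place of hydrogen on a saturated chain carbon, six bonds along the chain from an aromatic carbon, which gives a 1.7-fold lower number from compound 2 to compound 3 (0.23 log units; within the scatter) and shows that the two alkyl chains cannot be separated from each other on this read-out either. Across 3-chloropropyl, hexyl and octyl on the shared core, the three numbers therefore show no dependence on the chain, and no measurement here offers an explanation for that.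

Going by these compounds, whether an amine or a carboxylic acid at the end of the chain would move the number beyond the scatter remains open. So does the reading for a chain longer than octyl, or for a phenyl ring in its place.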